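The source may report more compounds than this note shows. Statements on the series, on what has been measured and on what is new or still open speak of the compounds shown alone.

In an assay on CHO cells for displacement of a labelled ligand from Neuronal acetylcholine receptor; alpha3/alpha6/beta2/beta3 (Homo sapiens), read by scintillation counting (on this read-out lower numbers stand for stronger inhibition and higher numbers for weaker inhibition), compound 1 `CCC(=O)N1CC2CC(C1)N2` gives 190 nM. Compound 2 `O=C([C@H]1C[C@H]1F)N1CC2CC(C1)N2` gives 27 nM and compound 3 `O=C([C@@H]1C[C@@H]1F)N1CC2CC(C1)N2` gives 55 nM in this assay. Among the compounds with values here, putting 2-fluorocyclopropyl in place of ethyl on the carbonyl carbon gave a 7.0-fold lower number from compound 1 to compound 2 (0.85 log units; beyond the scatter) and a 3.5-fold lower number from compound 1 to compound 3 (0.54 log units; beyond the scatter); inverting configuration on the 2-fluorocyclopropyl ring gave a 2.0-fold higher number from compound 2 to compound 3 (0.31 log units; beyond the scatter), where the fact that one of compounds 2 and 3 is drawn with a defined configuration and the other without, at the place where they differ is the only distinction between the pair. Compound 3 therefore stands second highest of the three numbers, nearest compound 2 and furthest from compound 1. Compound 4 `O=C([C@@H]1C[C@H]1F)N1CC2CC(C1)N2` keeps all atoms and bonds and differs only in configuration: the two compounds have the same atoms and bonds; at least one stereo element is drawn with a configuration in one of them and without one in the other: 1 of 4 stereo elements differ; a stereocentre at a saturated ring carbon is drawn S in compound 3 and R in compound 4. Within the data shown here, the one measured step that bears on configuration alone was modest, so a step of comparable size in this assay is expected, direction open. Compound 4 is expected to give 55 nM (range 15 nM to 200 nM), an expected step of no change at the digits printed from compound 3 to compound 4 (within the scatter).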

Compound 4, inhibition constant: 43 nM
The estimate for compound 4 lay 1.3-fold (0.11 log units) above the measured number; the range from low to high includes it.
By their numbers in this assay, from the lowest: compounds 2, 4 and 3 (each within the scatter of the next, the first and the last beyond it); then compound 1.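

In this assay, a single stereocentre change on the 2-fluorocyclopropyl ring stays within the scatter in both directions: a 1.3-fold lower number from compound 3 to compound 4 (0.11 log units; within the scatter) and a 1.6-fold higher number from compound 2 to compound 4 (0.20 log units; within the scatter). Compound 4 therefore sits within the scatter of both compound 2 and compound 3, so the configurations shown separate only weakly at this position. The gain over ethyl also holds for this third configuration: a 4.4-fold lower number from compound 1 to compound 4 (0.65 log units; beyond the scatter).

The compounds shown leave open how much of that gain belongs to the ring and how much to the fluorine. A plain cyclopropyl on the carbonyl would separate the two.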